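The source may report more compounds than this note shows. Statements on the series, on what has been measured and on what is new or still open speak of the compounds shown alone.

Three compounds share one core and differ only in the group on the amide-type nitrogen. Compound 1 `O=C(NCc1ccccc1)c1c(O)c2cccnc2n(-c2ccccc2)c1=O` gives 1.6% in a functional assay on the whole organism for inhibition, with Rattus norvegicus as the target, read by paw edema, at a dose of 100 mg/kg by the oral route; on this read-out lower numbers stand for less inhibition and higher numbers for more inhibition at the one dose given (going by the name of the read-out). Compound 2 `COc1cccc(NC(=O)c2c(O)c3cccnc3n(-c3ccccc3)c2=O)c1` gives 5.7%, and compound 3 `COc1ccccc1NC(=O)c1c(O)c2cccnc2n(-c2ccccc2)c1=O` gives 8.1%. Compound 3 holds the highest of the three numbers, yet every gap stays small: a number 6.5 percentage points higher from compound 1 to compound 3 (within the scatter), a number 2.4 percentage points higher from compound 2 to compound 3 (within the scatter), and a number 4.1 percentage points higher from compound 1 to compound 2 (within the scatter). Compound 4 `COc1ccc(NC(=O)c2c(O)c3cccnc3n(-c3ccccc3)c2=O)cn1` has not yet been measured; it differs from compound 3 as follows: 6-methoxypyridin-3-yl in place of 2-methoxyphenyl on an amide-type nitrogen. For the measured compounds named here, no measured step exchanges a ring of carbon only for a ring with one hetero atom, so none bears directly on this change. The steps that are known, each a change of the group on the amide-type nitrogen, all remain within the scatter, and the same is expected here, so the expected step is a number 1.1 percentage points lower from compound 3 to compound 4 (within the scatter), not beyond the scatter. Compound 4 is therefore estimated at 7%, with a range from 0% to 18%.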

Compound 4, a percentage reported as inhibition, in the whole organism at one dose (the size of the read-out at that dose, not a potency): 13.1%
For compound 4 the middle estimate is 6.1 percentage points below the measured one; the measured number falls inside the stated range.
By their numbers in this assay, from the lowest: compounds 1, 2, 3 and 4 (each within the scatter of the next, the first and the last beyond it).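

In this assay, 6-methoxypyridin-3-yl on the amide-type nitrogen gives a number 5 percentage points higher from compound 3 to compound 4 (within the scatter) and a number 7.4 percentage points higher from compound 2 to compound 4 (within the scatter), so exchanging a methoxyphenyl ring of carbon only for a ring with one hetero atom stays within the scatter in both cases. Set against benzyl, the same group gives a number 11.5 percentage points higher from compound 1 to compound 4 (beyond the scatter), the first step at this position to clear the scatter, though only modestly. Nothing available explains this step.

Whether the ring nitrogen itself matters stays open, as no compound shown carries an unsubstituted phenyl or pyridinyl ring on this nitrogen. Also open, on these data alone, is how the number would respond to an amine or a carboxylic acid on that ring, or to a longer chain in place of the methoxy group.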